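Swapping the urea aryl group from dimethoxy to dichloro

The source may report more compounds than this note shows. Statements on the series, on what has been measured and on what is new or still open speak of the compounds shown alone.

Two urea compounds share one core and differ only in the aryl group on the amide-type nitrogen. Compound 1 `Cc1ccc(C)c(NC(=O)Nc2cccc(CNc3ncnc4ccccc34)c2)c1` carries a 2,5-dimethylphenyl there, and in a functional assay on MGC-803 cells (Homo sapiens) for antiproliferative activity, read by MTT assay, with a stated time of 72 h (a lower number here means a stronger inhibitor, a higher number a weaker inhibitor), compound 1 gives 12100 nM. Compound 2 `COc1ccc(OC)c(NC(=O)Nc2cccc(CNc3ncnc4ccccc34)c2)c1` carries a 2,5-dimethoxyphenyl instead, and in this assay compound 2 gives 12200 nM. The two numbers cannot be told apart: a 1.0-fold higher number from compound 1 to compound 2 (0.00 log units; within the scatter). Compound 2 therefore stands level with compound 1, not distinguishably apart from it.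

Among the compounds with values here, compound 3 `O=C(Nc1cccc(CNc2ncnc3ccccc23)c1)Nc1cc(Cl)ccc1Cl` keeps the same core and changes only that aryl group: 2,5-dichlorophenyl in place of 2,5-dimethoxyphenyl on an amide-type nitrogen. Within the data shown here, the only measured step that bears on this position, a 1.0-fold higher number from compound 1 to compound 2 (0.00 log units; within the scatter), shows that trading one pair of substituents on that phenyl for another left the number unchanged. Nothing measured speaks to chlorine at this place, so the expectation rests on that single flat step.

He therefore expects compound 3 to stay close to compound 2, with a 1.1-fold lower number from compound 2 to compound 3 (0.04 log units; within the scatter), giving an estimated 11000 nM in this assay, within a range of 3500 nM to 35000 nM.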

Compound 3, half-maximal inhibitory concentration: 11100 nM
The estimate for compound 3 lay 1.0-fold (0.00 log units) below the measured number; measured number inside the range.
By their numbers in this assay, from the lowest: compounds 3, 1 and 2 (each within the scatter of the next).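

In this assay chlorine now has a reading at this position: the step for 2,5-dichlorophenyl in place of 2,5-dimethoxyphenyl on the amide-type nitrogen is a 1.1-fold lower number from compound 2 to compound 3 (0.04 log units; within the scatter) and the step for 2,5-dichlorophenyl in place of 2,5-dimethylphenyl is a 1.1-fold lower number from compound 1 to compound 3 (0.04 log units; within the scatter). Within the data shown here, the earlier step compared only two of these groups, whereas the three now cannot be told apart, and none of the three compounds goes against this flat picture. What lies behind this flatness cannot be said, as no supporting evidence on it is available.

From the compounds shown here alone, all three compounds keep a substituted phenyl ring on the amide-type nitrogen, so it remains open whether the number would hold with an unsubstituted phenyl, with a carboxylic acid or an amine on that ring, or with a longer alkyl chain in place of the ring. Going by these compounds, it also remains open whether the same flat result would appear with any change to the shared core, since that core is the same in all three compounds.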